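From pyridin-3-yl to pyridin-4-yl: what to expect

The compounds below may be only part of what the source reports. "The series", "measured", "known", "first", "only" and "open" are said of these compounds alone.

compound 1 `O=C1/C(=C/c2cccnc2)CN(S(=O)(=O)c2ccc(C(F)(F)F)cc2)C/C1=C\c1ccccc1F`: 11300 nM
compound 2 `O=C1/C(=C/c2cccnc2)CN(S(=O)(=O)c2ccc(F)cc2)C/C1=C\c1ccccc1F`: 15600 nM
compound 3 `O=C1/C(=C/c2cccnc2)CN(S(=O)(=O)c2ccc(Br)cc2)C/C1=C\c1ccccc1F`: 14600 nM

These values come from an ADME assay on L02 cells (Homo sapiens) for cytotoxicity, read by MTT assay, with a stated time of 24 h (on this read-out lower numbers stand for stronger inhibition and higher numbers for weaker inhibition), and the three compounds differ in one group on an aromatic carbon: trifluoromethyl, fluoro or bromo. Compound 1 does not stand apart from the other two. The data show a 1.3-fold higher number from compound 1 to compound 3 (0.11 log units; within the scatter) and a 1.4-fold higher number from compound 1 to compound 2 (0.14 log units; within the scatter) so no ranking among them can be claimed.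

Compound 4 `O=C1/C(=C/c2ccncc2)CN(S(=O)(=O)c2ccc(C(F)(F)F)cc2)C/C1=C\c1ccccc1F` has yet to be measured. It keeps the trifluoromethyl group of compound 1 and alters another part of the molecule: pyridin-4-yl in place of pyridin-3-yl on a double-bonded chain carbon bound to a double-bonded ring carbon on a double-bonded chain carbon bound to a double-bonded ring carbon. The two compounds have the same atoms, joined differently.

Among the measured compounds shown here, no measured step touches this place, so none tests the change directly. For the measured compounds named here, they show only that swaps elsewhere have barely moved this assay so far, as in a 1.1-fold lower number from compound 2 to compound 3 (0.03 log units; within the scatter) for the third pair. A step beyond the scatter is therefore not expected, though this rests on indirect evidence. Going by the values given here, the estimate stays close to compound 1 at 11300 nM as the only measured compound with the same trifluoromethyl group. The expected change is a 1.1-fold higher number from compound 1 to compound 4 (0.03 log units; within the scatter) according to this estimate. The expected value for compound 4 is 12000 nM with an estimated range from 7000 nM to 21000 nM in this assay for now.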

Compound 4, half-maximal inhibitory concentration: 18600 nM
Compound 4: middle estimate off by 1.6-fold (0.19 log units), on the low side; the range from low to high includes it.
By their numbers in this assay, from the lowest: compounds 1, 3, 2 and 4 (each within the scatter of the next).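

Among the compounds shown here, this is the first comparison at this position, on a double-bonded chain carbon bound to a double-bonded ring carbon, and in this assay it gives a 1.6-fold higher number from compound 1 to compound 4 (0.22 log units; within the scatter). Pyridin-3-yl and pyridin-4-yl have the same atoms and the same counts of donors and acceptors, so the pair tests only how those atoms are joined, and on this evidence that difference does not carry the assay beyond the usual scatter at this position. Nothing in the available data explains why the step has this size.

This single pair, with trifluoromethyl on the other aromatic ring, leaves open whether the same swap would stay within the scatter with fluoro or bromo there instead. It also leaves open how the assay would respond to larger changes at this position, such as a plain phenyl ring or a pyridine ring carrying an amine or a carboxylic acid.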